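This account rests on a few compounds, and the source may have more. Where it says the series, first, only, none or still open, it means among the compounds named here.

Measured in a functional assay on T-24 cells (Homo sapiens) for antiproliferative activity, read by MTT assay, with a stated time of 48 h; on this read-out higher numbers stand for weaker inhibition and lower numbers for stronger inhibition:
- compound 1 `Cc1ccc(NC(=O)Nc2cccc(CNc3nccnc3Cl)c2)c(C)c1`: 9230 nM
- compound 2 `O=C(Nc1cccc(CNc2nccnc2Cl)c1)NC1CCCC1`: > 40000 nM (a limit, not a number)
- compound 3 `Cc1ccccc1NC(=O)Nc1cccc(CNc2nccnc2Cl)c1`: 13600 nM

In this assay compound 3 gives 13600 nM, which lies within the scatter of compound 1. Compound 4 `O=C(Nc1cccc(CNc2nccnc2Cl)c1)Nc1ccccc1Cl` carries chloro in place of methyl on an aromatic carbon, ortho to a large group (chloro in place of methyl on an aromatic carbon). The closest guide is another small change on that ring, hydrogen in place of methyl, a 1.5-fold higher number from compound 1 to compound 3 (0.17 log units; within the scatter), which stayed within the scatter. The clear step, an at least 2.9-fold lower number from compound 2 to compound 3 (0.46 log units; beyond the scatter), replaced a whole group, 2-methylphenyl in place of cyclopentyl, and the new compound keeps its aromatic ring. No shift beyond the scatter is therefore expected, and the estimated step is a 1.2-fold lower number from compound 3 to compound 4 (0.09 log units; within the scatter). Compound 4 is expected at 11000 nM, within an estimated range of 5000 nM to 25000 nM.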

Compound 4, half-maximal inhibitory concentration: 6680 nM
Compound 4: the middle estimate sits 1.6-fold (0.22 log units) above what was measured; measured number inside the range.
By their numbers in this assay, from the lowest: compounds 4, 1 and 3 (each within the scatter of the next, the first and the last beyond it). At a limit, above all of these: compound 2.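

On an aromatic carbon ortho to a large group, chloro in place of methyl gives a real shift in this assay: a 2.0-fold lower number from compound 3 to compound 4 (0.31 log units; beyond the scatter). The 2-chlorophenyl and 2,4-dimethylphenyl groups, however, cannot be ranked: a 1.4-fold lower number from compound 1 to compound 4 (0.14 log units; within the scatter). Compound 2 stands at a limit, not a number, so its step to the 2-chlorophenyl compound is only a bound, an at least 5.9-fold lower number from compound 2 to compound 4 (0.77 log units; beyond the scatter): the limit of > 40000 nM in this assay, at which 1 of the 4 values shown sits.

Going by these compounds, whether a methoxy group or an amine at this position would keep, strengthen or lose this inhibition remains open.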